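A single-point comparison across an amine substituent

The compounds below may be only part of what the source reports. "The series", "measured", "known", "first", "only" and "open" are said of these compounds alone.

Measured compounds:
- compound 1, `COc1cc(Nc2ncccc2-c2nc(Nc3cc(OC)ccc3OC)n[nH]2)cc(OC)c1`: 20%
- compound 2, `COc1cc(Nc2ncccc2-c2n[nH]c(Nc3ccc(N(C)C)cc3)n2)cc(OC)c1`: "not determined" (no result reported)
- compound 3, `COc1cc(Nc2ncccc2-c2n[nH]c(Nc3ccc(C#N)cc3)n2)cc(OC)c1`: "not determined" (no result reported)

Among the compounds with values here, only one number is in hand. In a functional assay on A-431 cells (Homo sapiens), tested at 0.1 uM (on this read-out lower numbers stand for less inhibition and higher numbers for more inhibition at the one concentration tested (going by the name of the read-out)), compound 1 gives 20%, a modest degree of inhibition at the single concentration tested. Within the data shown here, compound 2 and compound 3 share the core of compound 1 but carry other groups on the same nitrogen; for both of them no result was reported in this assay, so they offer no step against which to judge compound 1. Compound 1 therefore stands alone on the numbers shown.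

Compound 4, `COc1ccc(CNc2n[nH]c(-c3cccnc3Nc3cc(OC)cc(OC)c3)n2)cc1`, differs from compound 1 in one place: 4-methoxybenzyl in place of 2,5-dimethoxyphenyl on a nitrogen on an aromatic ring. The group that leaves has two oxygen atoms and the group that enters has one, and the entering group adds a carbon between the nitrogen and the ring.

Among the measured compounds shown here, with no measured step of this kind, the expected change from compound 1 to compound 4 is estimated to be small, within the usual scatter, as a number 5 percentage points lower from compound 1 to compound 4 (within the scatter). Compound 4 is expected to give 15% in this assay, with a range from 0% to 40%.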

Compound 4, a percentage reported as inhibition, at one concentration (the size of the read-out at that concentration, not a potency): 22%
Beside the measured number, compound 4's estimate is 7 percentage points below it, within the range that was stated.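

In this assay, within the data shown here, the change to 4-methoxybenzyl in place of 2,5-dimethoxyphenyl on a nitrogen on an aromatic ring gives a number 2 percentage points higher from compound 1 to compound 4 (within the scatter) and so provides the first measured step at this position. That step lies within the scatter, so the two groups are not told apart by this read-out, even though the entering group adds a carbon between the nitrogen and the ring and carries one oxygen fewer. Nothing at hand explains this outcome.

The compounds shown leave open whether a longer chain on this nitrogen, such as 2-phenylethyl, would move the inhibition away from this level. They also leave open whether an unsubstituted benzyl group would match 4-methoxybenzyl, and so whether the methoxy group on the benzyl ring matters here.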